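The compounds below may be only part of what the source reports. "The series", "measured", "known", "first", "only" and "open" are said of these compounds alone.

Measured compounds:
- Compound 1 `COc1cccc(-c2c(C)n(Cc3c(F)cccc3F)c(=O)n(C[C@@H](N)C3CCCC3)c2=O)c1F` gives 94 nM in an assay on HEK293 cells for binding affinity to Gonadotropin-releasing hormone receptor (Homo sapiens), read by radioligand binding; a lower number here means a stronger inhibitor, a higher number a weaker inhibitor.
- Compound 2 `COc1cccc(-c2c(C)n(Cc3c(F)cccc3F)c(=O)n(C[C@H](NC(C)C)C3CCCCC3)c2=O)c1F` gives 23 nM in this assay.
- Compound 3 `CN[C@H](CC(C)C)Cn1c(=O)c(-c2cccc(OC)c2F)c(C)n(Cc2c(F)cccc2F)c1=O` gives 1.2 nM in this assay.

Compound 3 stands lowest of the three numbers; it lies a 19-fold lower number from compound 2 to compound 3 (1.28 log units; beyond the scatter) and a 78-fold lower number from compound 1 to compound 3 (1.89 log units; beyond the scatter), both beyond the scatter. Compound 4 `COc1cccc(-c2c(C)n(Cc3c(F)cccc3F)c(=O)n(C[C@@H](N)C(C)C)c2=O)c1F` differs from compound 3 by 1-amino-2-methylpropyl in place of 3-methyl-1-(methylamino)butyl on a saturated chain carbon bound to an aromatic nitrogen. Among the compounds with values here, two measured steps bear on this change. Compound 1, which also carries a free amino group on that carbon, lies far from compound 3: a 78-fold lower number from compound 1 to compound 3 (1.89 log units; beyond the scatter). Compound 2, with an isopropylamino group, lies closer: a 19-fold lower number from compound 2 to compound 3 (1.28 log units; beyond the scatter). Compound 4 thus returns to the free amino group of compound 1 while keeping a short chain, as in compound 3, in place of a ring. In this assay compound 4 is therefore expected to give a higher number than compound 3, with the step estimated at a 33-fold higher number from compound 3 to compound 4 (1.52 log units; beyond the scatter). The estimate for compound 4 is 40 nM, with a range from 8 nM to 200 nM.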

Compound 4, inhibition constant: 973 nM
Beside the measured number, compound 4's estimate is 24-fold (1.39 log units) below it; the whole stated range lies below it.
By their numbers in this assay, from the lowest: compound 3; then compound 2; then compound 1; then compound 4.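

With the free amino group held in place, isopropyl in place of cyclopentyl gives a 10-fold higher number from compound 1 to compound 4 (1.01 log units; beyond the scatter) in this assay, so an open chain on this carbon does not by itself reproduce the strength of compound 3. The full replacement gives an 810-fold higher number from compound 3 to compound 4 (2.91 log units; beyond the scatter), the largest step among these compounds, and a 42-fold higher number from compound 2 to compound 4 (1.63 log units; beyond the scatter) shows that the cyclohexyl(isopropylamino)methyl group of compound 2, despite its ring, stands far lower in number than 1-amino-2-methylpropyl. No measured information here explains these steps.

Compounds 3 and 4 differ in both the nitrogen substituent and the carbon chain, so the shares of the methylamino group and the 3-methylbutyl chain in this step remain unseparated. A free amine on the 3-methylbutyl chain, or a methylamino group on the isopropyl-bearing carbon, would divide them.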